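This account rests on a few compounds, and the source may have more. Where it says the series, first, only, none or still open, it means among the compounds named here.

Measured so far in a functional assay on BT-474 cells (Homo sapiens) for inhibition, read by fluorescence, with a stated time of 72 h; on this read-out higher numbers stand for weaker inhibition of growth and lower numbers for stronger inhibition of growth 
compound 1 `CCCCCCn1cnc2c(Nc3ccc(Cl)cc3)nc(N[C@H]3CC[C@H](N)CC3)nc21` gives 5500 nM 
compound 2 `CCCCCCn1cnc2c(Nc3ccc(O)cc3)nc(N[C@H]3CC[C@H](N)CC3)nc21` gives 7700 nM 

Compound 2 at 7700 nM lies within the scatter of compound 1, so neither stands apart. Compound 3 `CCCCCCn1cnc2c(Nc3cccc(Cl)c3)nc(N[C@H]3CC[C@H](N)CC3)nc21` departs from compound 2 by one change (3-chlorophenyl in place of 4-hydroxyphenyl on a nitrogen on an aromatic ring), namely 3-chlorophenyl in place of 4-hydroxyphenyl on a nitrogen on an aromatic ring. Among the compounds with values here, the only measured step bearing on this, hydroxy in place of chloro on an aromatic carbon, is small and within the scatter (a 1.4-fold higher number from compound 1 to compound 2 (0.15 log units; within the scatter)). The expected change is therefore none beyond the scatter (a 1.3-fold lower number from compound 2 to compound 3 (0.11 log units; within the scatter)). Compound 3 is expected at 6000 nM with an estimated range (2500 nM to 14000 nM).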

Compound 3, concentration for 50% growth inhibition: 5100 nM
For compound 3 the middle estimate is 1.2-fold (0.07 log units) above the measured one, and the stated range covers the measured number.
By their numbers in this assay, from the lowest: compounds 3, 1 and 2 (each within the scatter of the next).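

In this assay, 3-chlorophenyl in place of 4-chlorophenyl on a nitrogen on an aromatic ring gives a 1.1-fold lower number from compound 1 to compound 3 (0.03 log units; within the scatter), and 3-chlorophenyl in place of 4-hydroxyphenyl gives a 1.5-fold lower number from compound 2 to compound 3 (0.18 log units; within the scatter). Across these three groups at this position, neither changing 4-chloro to 3-chloro nor replacing 4-hydroxy with 3-chloro moves the number beyond the scatter. No evidence bears on this result.

Still open, from the compounds shown here alone, is whether an amine or a carboxylic acid on this phenyl ring would give a number beyond the scatter. Going by these compounds, whether 3-hydroxyphenyl would match 3-chlorophenyl is also open.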